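Aryl ketone variation on the coumarin hydrazide series

A few compounds are considered here, and "the series" means these few. Any claim that something is new, unique, unknown or untested is made for them only; others in the source may bear on it.

Measured so far in a functional assay on Ehrlich cells (Mus musculus) for cytotoxicity, read by MTT assay, with a stated time of 48 h; on this read-out lower numbers stand for stronger inhibition and higher numbers for weaker inhibition:
compound 1 `Cc1ccc(OCC(=O)NNC(=O)c2cc3ccccc3oc2=O)c(C(=O)c2cccc(Cl)c2)c1` gives 64900 nM
compound 2 `Cc1ccc(OCC(=O)NNC(=O)c2cc3ccccc3oc2=O)c(C(=O)c2ccccc2)c1` gives 78400 nM
compound 3 `Cc1ccc(OCC(=O)NNC(=O)c2cc3ccccc3oc2=O)c(C(=O)c2ccc(Cl)cc2)c1` gives 56600 nM

Compound 1 sits in the middle of the three numbers; the nearest is compound 3, a 1.1-fold lower number from compound 1 to compound 3 (0.06 log units; within the scatter), and the furthest is compound 2, a 1.2-fold higher number from compound 1 to compound 2 (0.08 log units; within the scatter). Neither gap separates the compounds.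

Compound 4 `Cc1ccc(C(=O)c2cc(C)ccc2OCC(=O)NNC(=O)c2cc3ccccc3oc2=O)cc1` differs from compound 1 by 4-methylphenyl in place of 3-chlorophenyl on a carbonyl carbon. Among the compounds with values here, the steps that bear on it are the other aryl exchanges at this carbonyl carbon: a 1.2-fold higher number from compound 1 to compound 2 (0.08 log units; within the scatter), a 1.1-fold lower number from compound 1 to compound 3 (0.06 log units; within the scatter) and a 1.4-fold lower number from compound 2 to compound 3 (0.14 log units; within the scatter). All three stay within the scatter. Within the data shown here, no measured step covers a methyl on this ring, so the expectation rests only on these. Compound 4 is therefore expected to show no step beyond the scatter, a 1.0-fold higher number from compound 1 to compound 4 (0.00 log units; within the scatter), with an estimate of 65000 nM (range 35000 nM to 120000 nM).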

Compound 4, half-maximal inhibitory concentration: 78100 nM
Beside the measured number, compound 4's estimate is 1.2-fold (0.08 log units) below it; measured number inside the range.
By their numbers in this assay, from the lowest: compounds 3, 1, 4 and 2 (each within the scatter of the next).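

In this assay, a methyl group on the aryl ring at this carbonyl carbon does not separate from the groups already seen there, with each step within the scatter (a 1.2-fold higher number from compound 1 to compound 4 (0.08 log units; within the scatter)) (a 1.4-fold higher number from compound 3 to compound 4 (0.14 log units; within the scatter)) (a 1.0-fold lower number from compound 2 to compound 4 (0.00 log units; within the scatter)). The four aryl groups at this position, 4-methylphenyl, 3-chlorophenyl, 4-chlorophenyl and phenyl, therefore remain unresolved from one another. No available evidence offers an explanation for this result. Still open, on these data alone, is whether an amine or a carboxylic acid on this ring would produce a step beyond the scatter.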